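Aryl-piperazine dithiocarbamates on the shared core: methyl to chloro

The source may hold more compounds than are shown below. What is called first, only, known or untested is meant among the compounds shown, and "the series" means these compounds.

Compound 1 `Nc1nc(N)c2cc(CSC(=S)N3CCN(C4CCCCC4)CC3)ccc2n1` and compound 2 `Cc1ccccc1N1CCN(C(=S)SCc2ccc3nc(N)nc(N)c3c2)CC1` share the core and differ only at the amine nitrogen in the ring. In a functional assay on HT-29 cells (Homo sapiens) for antiproliferative activity, read by MTT assay, with a stated time of 72 h (on this read-out lower numbers stand for stronger inhibition and higher numbers for weaker inhibition), compound 1 gives 4050 nM, and compound 2 gives 2950 nM; the step of a 1.4-fold lower number from compound 1 to compound 2 (0.14 log units; within the scatter) leaves the two within the scatter of each other. Compound 3 `Nc1nc(N)c2cc(CSC(=S)N3CCN(c4ccccc4Cl)CC3)ccc2n1` differs from compound 2 by chloro in place of methyl on an aromatic carbon. Going by the values given here, no measured step touches this position, and the one step known is within the scatter, so no step beyond the scatter is expected in this assay. Compound 3 is expected at 3000 nM, within 1400 nM to 6500 nM, which means an expected step of a 1.0-fold higher number from compound 2 to compound 3 (0.01 log units; within the scatter).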

Compound 3, half-maximal inhibitory concentration: 3900 nM
For compound 3 the middle estimate is 1.3-fold (0.11 log units) below the measured one; the measured number falls inside the stated range.
By their numbers in this assay, from the lowest: compounds 2, 3 and 1 (each within the scatter of the next).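

In this assay, chloro in place of methyl on an aromatic carbon, ortho to a large group, gives (a 1.3-fold higher number from compound 2 to compound 3 (0.12 log units; within the scatter)), and 2-chlorophenyl in place of cyclohexyl on the amine nitrogen gives (a 1.0-fold lower number from compound 1 to compound 3 (0.02 log units; within the scatter)). The aromatic carbon now has its first measured step, and compounds 1, 2 and 3 all lie within the scatter of each other. No evidence on hand bears on this result.

On these data alone, what an amine or a carboxylic acid on this aromatic carbon would give remains open. Also open, as far as these compounds go, is whether any group on the amine nitrogen gives a step beyond the scatter.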